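The source may report more compounds than this note shows. Statements on the series, on what has been measured and on what is new or still open speak of the compounds shown alone.

Among the compounds with values here, compound 3 `CCOC(=O)/C=C/C(=O)N(CC(N)=O)NC(=O)[C@@H]1CCCN1C(=O)C1(NC(C)=O)CC1` gives 9.3 nM in an assay on isolated protein for inhibition of legumain (Mus musculus), read by fluorescence, with stated times of 30 s and 2.5 h (a lower number here means a stronger inhibitor, a higher number a weaker inhibitor), the lowest of the three numbers measured so far; compound 1 `CCOC(=O)/C=C/C(=O)N(CC(N)=O)NC(=O)[C@@H]1CCCN1C(=O)[C@H]1CSCN1C(C)=O` gives 167 nM and compound 2 `CCOC(=O)/C=C/C(=O)N(CC(N)=O)NC(=O)[C@@H]1CCCN1C(=O)[C@H]1CCCCN1C(C)=O` gives 638 nM. Compound 4 `CCOC(=O)/C=C/C(=O)N(CC(N)=O)NC(=O)[C@@H]1CCCN1C(=O)C(C)(C)NC(C)=O` differs from compound 3 only by 1-acetamido-1-methylethyl in place of 1-acetamidocyclopropyl on a carbonyl carbon. The measured steps all concern this same carbonyl position: an 18-fold lower number from compound 1 to compound 3 (1.25 log units; beyond the scatter) and a 69-fold lower number from compound 2 to compound 3 (1.84 log units; beyond the scatter), while a 3.8-fold higher number from compound 1 to compound 2 (0.58 log units; beyond the scatter). Every swap at this position moved the number well beyond the scatter, yet none of them replaced the three-membered ring with a group having no ring, so the direction of the present step is uncertain. A small loss is expected, a 2.7-fold higher number from compound 3 to compound 4 (0.43 log units; beyond the scatter). Compound 4 is therefore estimated at 25 nM, with a range from 8 nM to 80 nM.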

Compound 4, half-maximal inhibitory concentration: 198 nM
Compound 4: the middle estimate sits 7.9-fold (0.90 log units) below what was measured; measured number outside the range, above it.
By their numbers in this assay, from the lowest: compound 3; then compounds 1 and 4 (each within the scatter of the next); then compound 2.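

Replacing the three-membered carbon ring with a group of the same heavy-atom count but no ring gives a large change in this assay (a 21-fold higher number from compound 3 to compound 4 (1.33 log units; beyond the scatter)), so at this position the low number goes with that ring and not with the atom count alone. The ring-free group still improves on the six-membered ring of compound 2 (a 3.2-fold lower number from compound 2 to compound 4 (0.51 log units; beyond the scatter)), yet cannot be told apart from the five-membered ring of compound 1 (a 1.2-fold higher number from compound 1 to compound 4 (0.07 log units; within the scatter)). No measured evidence accounts for these steps.
Open, as far as these compounds go, is whether a cyclobutyl ring would keep the low number. Also open, from the compounds shown here alone, is the effect of a longer chain, such as butanoyl, in place of the acetyl.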